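The compounds below may be only part of what the source reports. "The series", "measured", "known", "first", "only" and "open" are said of these compounds alone.

Working notes on the series:

- compound 1 `CCCCOC(=O)Nc1cc2nc(C3CCCCC3)[nH]c2cc1Oc1ccc(F)cc1`: 60000 nM
- compound 2 `C=CCCC(=O)Nc1cc2nc(C3CCCCC3)[nH]c2cc1Oc1ccc(F)cc1`: > 200000 nM (a limit)
- compound 3 `COc1ccc(C(=O)Nc2cc3nc(C4CCCCC4)[nH]c3cc2Oc2ccc(F)cc2)cc1`: not yet measured

Among the compounds with values here, in an ADME assay on Vero cells (Chlorocebus sabaeus) for cytotoxicity, read by MTT assay, with a stated time of 2 days (a lower number here means a stronger inhibitor, a higher number a weaker inhibitor), compound 1 gives 60000 nM, the only actual number so far. Compound 3 differs from it as follows: 4-methoxyphenyl in place of butoxy on a carbonyl carbon, with 4-methoxyphenyl in place of butoxy on a carbonyl carbon. Within the data shown here, one measured step bears on this change, at the same carbonyl carbon: an at least 3.3-fold higher number from compound 1 to compound 2 (0.52 log units; beyond the scatter). On that single step, a modest move to a higher number is expected in this assay. The expected change is a 1.7-fold higher number from compound 1 to compound 3 (0.22 log units; within the scatter). For compound 3 the estimated value is 100000 nM, with an expected range of 35000 nM to 200000 nM.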

Compound 3, half-maximal inhibitory concentration: 40000 nM
Beside the measured number, compound 3's estimate is 2.5-fold (0.40 log units) above it; low and high end bracket the measured number.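

Replacing butoxy with 4-methoxyphenyl, which brings a six-membered aromatic ring to the carbonyl carbon, gives a 1.5-fold lower number from compound 1 to compound 3 (0.18 log units; within the scatter) in this assay, so this ring does not shift the read-out beyond the scatter. Against but-3-en-1-yl, the same ring gives an at least 5.0-fold lower number from compound 2 to compound 3 (0.69 log units; beyond the scatter), so leaving butoxy does not by itself carry the number upward. Compound 2 is read only as a limit of the assay: the limit of > 200000 nM in this assay, at which 1 of the 3 values shown sits.

The compounds shown leave open how a chain bearing an amine or a carboxylic acid on this carbonyl carbon would read in this assay. Going by these compounds, whether an unsubstituted phenyl reads like 4-methoxyphenyl also stays open.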